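Ortho-methyl on the N-phenyl: effect on solubility

The compounds below may be only part of what the source reports. "The series", "measured", "known", "first", "only" and "open" are said of these compounds alone.

Measured so far:
compound 1 `CCc1ccc(-c2nc3c(c(C)nn3-c3ccccc3)c(-c3ccccc3O)c2C#N)cc1` — 3100 nM
compound 2 `Cc1nn(-c2ccccc2)c2nc(-c3ccc(C#N)cc3)c(C#N)c(-c3ccccc3O)c12` — 1700 nM

For the measured compounds named here, in a physicochemical assay for solubility, read by spectrophotometry, in phosphate buffer, with a stated time of 18 h, at pH 7.4 (a higher number here means a more soluble compound, a lower number a less soluble compound), compound 1 gives the higher of the two numbers so far, but only by a 1.8-fold lower number from compound 1 to compound 2 (0.26 log units; within the scatter), so the two values are not distinguished. Compound 3 `CCc1ccc(-c2nc3c(c(C)nn3-c3ccccc3C)c(-c3ccccc3O)c2C#N)cc1` differs from compound 1 by methyl in place of hydrogen on an aromatic carbon. Going by the values given here, no measured step touches this position: the single step recorded, from compound 1 to compound 2, concerns a different ring and stayed within the scatter, so it gives no direct guide. Small additions of this kind have in other series moved solubility in either direction, seldom far. The expectation is therefore a step of a 1.4-fold lower number from compound 1 to compound 3 (0.15 log units; within the scatter), no larger than the scatter, with a slight lean towards a lower number. Compound 3 is estimated at 2200 nM in this assay, with a range from 900 nM to 5500 nM.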

Compound 3, solubility: 9600 nM
For compound 3 the middle estimate is 4.4-fold (0.64 log units) below the measured one, outside the stated range (above it).
By their numbers in this assay, from the lowest: compounds 2 and 1 (each within the scatter of the next); then compound 3.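

In this assay, for the compounds shown here, the change from phenyl to 2-methylphenyl gives a 3.1-fold higher number from compound 1 to compound 3 (0.49 log units; beyond the scatter) and so is the first change to separate two compounds. The only earlier step (a 1.8-fold lower number from compound 1 to compound 2 (0.26 log units; within the scatter)) concerned a different ring and stayed within the scatter, so this position is the one place shown where a single added methyl moves the read-out, and it moves it towards higher solubility. Nothing available accounts for the size or direction of this step.

From the compounds shown here alone, whether an ethyl, a methoxy or an amine in the same place would give a step in the same direction remains open. Going by these compounds, it is also open whether the same methyl would raise the number on the core of compound 2, which carries the nitrile in place of the ethyl.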